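Removing the aryl methyl: expected cytotoxicity of compound 4

The source may hold more compounds than are shown below. What is called first, only, known or untested is meant among the compounds shown, and "the series" means these compounds.

Compound 1, `COc1cc2c(cc1OC)CN(S(=O)(=O)c1ccc(-n3cc(COc4ccccc4C(C)=O)nn3)cc1)CC2`, reaches only a limit of > 50 ug/mL in a functional assay on HuCC-A1 cells (Homo sapiens) for cytotoxicity, read by MTT assay, with a stated time of 48 h; on this read-out lower numbers stand for stronger inhibition and higher numbers for weaker inhibition.
Compound 2, `COc1cc2c(cc1OC)CN(S(=O)(=O)c1ccc(-n3cc(COc4ccc([N+](=O)[O-])cc4)nn3)cc1)CC2`, likewise reaches only a limit of > 50 ug/mL in this assay.
Compound 3, `COc1cc2c(cc1OC)CN(S(=O)(=O)c1ccc(-n3cc(COc4ccc(C)cc4)nn3)cc1)CC2`, also reaches only a limit of > 50 ug/mL in this assay.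

All three measured compounds share the same core and differ only in the aryl group carried on the oxygen on a saturated carbon. In this assay none of them gives a number: each sits at the limit (the limit of > 50 ug/mL in this assay, at which 3 of the 3 values shown sit). Accordingly the steps from compound 1 to compound 2 a step that the two limits leave unreadable from compound 1 to compound 2, from compound 1 to compound 3 a step that the two limits leave unreadable from compound 1 to compound 3 and from compound 2 to compound 3 a step that the two limits leave unreadable from compound 2 to compound 3 cannot be read in size or direction. Compound 3 therefore stands nowhere in particular among them; its value is a limit like the other two.

Compound 4, `COc1cc2c(cc1OC)CN(S(=O)(=O)c1ccc(-n3cc(COc4ccccc4)nn3)cc1)CC2`, differs from compound 3 in one place: hydrogen in place of methyl on an aromatic carbon. Going by the values given here, the two measured steps that end at compound 3 touch the same aromatic ring, but both are unreadable, so no measured step gives a readable size for this change. With three compounds at the limit, the step from compound 3 to compound 4 is expected to be a step that the limit leaves unreadable from compound 3 to compound 4, that is, nothing beyond the scatter. For compound 4 in this assay the estimate is 70 ug/mL, with a range from 30 ug/mL to 200 ug/mL, and most likely only a limit will again be reported.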

Compound 4, half-maximal inhibitory concentration: > 50 ug/mL
Compound 4 was reported as a limit; the forecaster's own chance of this, stated with the estimate: 85%; the middle value lies beyond the limit too.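

In this assay compound 4 gives > 50 ug/mL, which is a limit and not a number. The steps from compound 1, compound 2 and compound 3 to compound 4 cannot be read in size or direction, because all four compounds stand at the same limit: the limit of > 50 ug/mL in this assay, at which 4 of the 4 values shown sit.

The compounds shown leave open whether any aryl group on the shared core gives a readable value in this assay.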